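Hydroxy Added Next to the Amide: Three Limits, One Unknown

The source may report more compounds than this note shows. Statements on the series, on what has been measured and on what is new or still open speak of the compounds shown alone.

Compound 2 `O=C(Nc1ccccc1)c1cccc(Br)c1` is a simple bromo-substituted benzanilide. In an assay for inhibition of HSP60/HSP10 (Homo sapiens), with a stated time of 60 min (a higher number here means a weaker inhibitor, a lower number a stronger inhibitor), compound 2 gives only a limit of the assay, > 100000 nM. Compound 1 `O=C(Nc1ccccc1)c1cc(Br)ccc1O` carries a hydroxy group in place of a hydrogen on an aromatic carbon (hydroxy in place of hydrogen on an aromatic carbon). In this assay compound 1 likewise gives only a limit, > 100000 nM. The step that the two limits leave unreadable from compound 2 to compound 1 therefore cannot be read, since both values sit at the limit of > 100000 nM in this assay, at which 3 of the 3 values shown sit.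

Compound 3 `O=C(Nc1ccc(Sc2nc3ccccc3s2)cc1)c1cccc(Br)c1` carries a larger group on the anilide side; how its core differs from that of compound 2 is not broken down here. In this assay compound 3 also gives only a limit, > 100000 nM.

Compound 4 `O=C(Nc1ccc(Sc2nc3ccccc3s2)cc1)c1cc(Br)ccc1O` is compound 3 with the same kind of change, (hydroxy in place of hydrogen on an aromatic carbon); here the hydroxy sits ortho to a large group, whereas in compound 1 it sits ortho to a group of 9 heavy atoms. Because every value shown rests at the limit of > 100000 nM in this assay, at which 3 of the 3 values shown sit, and because a step that the two limits leave unreadable from compound 2 to compound 1 could not be read, the step of a number no higher from compound 3 to compound 4 (the limit leaves the size open) is expected to be small or itself unreadable. Compound 4 is therefore estimated to give about 100000 nM, most likely reported again as a limit, before the measurement is known.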

Compound 4, half-maximal inhibitory concentration: > 100000 nM
Compound 4: no number, only a limit; the forecaster's own chance of this, stated with the estimate: 80%; the middle value lies on the limit itself.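

In this assay compound 4 gives > 100000 nM, which is a limit of the assay and not a number. No size can be read for the change from compound 3 to compound 4, because both values are limits: the limit of > 100000 nM in this assay, at which 4 of the 4 values shown sit. The compounds shown leave open whether hydroxy in place of hydrogen changes inhibition at all.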